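Aryl in place of alkyl on the ring-nitrogen oxygen

This account rests on a few compounds, and the source may have more. Where it says the series, first, only, none or still open, it means among the compounds named here.

Measured compounds:
Compound 1 `CCCCCON1C(=O)[C@@H](NC(=O)OCCCCC2CCCCC2)[C@@H]1C`: 387 nM
Compound 2 `CCCCCCCON1C(=O)[C@@H](NC(=O)OCCCCC2CCCCC2)[C@@H]1C`: 2230 nM
Compound 3 `C[C@H]1[C@H](NC(=O)OCCCCC2CCCCC2)C(=O)N1Oc1ccc(C(F)(F)F)cc1`: 31 nM

In an assay on HEK293 cells for inhibition of N-acylethanolamine-hydrolyzing acid amidase (Homo sapiens), read by fluorescence, with stated times of 10 min and 50 min (on this read-out lower numbers stand for stronger inhibition and higher numbers for weaker inhibition), compound 2 has the highest of the three numbers. Its nearest neighbour is compound 1, separated by a 5.8-fold higher number from compound 1 to compound 2 (0.76 log units; beyond the scatter); its furthest is compound 3, separated by a 72-fold lower number from compound 2 to compound 3 (1.86 log units; beyond the scatter).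

Compound 4 `COC(=O)c1ccc(ON2C(=O)[C@@H](NC(=O)OCCCCC3CCCCC3)[C@@H]2C)cc1` differs from compound 2 by 4-(methoxycarbonyl)phenyl in place of heptyl on an oxygen. For the measured compounds named here, two measured steps bear on this: a 72-fold lower number from compound 2 to compound 3 (1.86 log units; beyond the scatter) and a 12-fold lower number from compound 1 to compound 3 (1.10 log units; beyond the scatter), both large and both in the lowering direction when an aryl group replaces an alkyl chain on that oxygen. A large lowering step is therefore expected in this assay for compound 4, a 37-fold lower number from compound 2 to compound 4 (1.57 log units; beyond the scatter). Compound 4 is estimated at 60 nM, with a range from 15 nM to 250 nM.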

Compound 4, half-maximal inhibitory concentration: 17 nM
Compound 4: middle estimate off by 3.5-fold (0.55 log units), on the high side; the measured number falls inside the stated range.
By their numbers in this assay, from the lowest: compounds 4 and 3 (each within the scatter of the next); then compound 1; then compound 2.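

In this assay a second aryl group on the oxygen also beats both alkyl chains, with a 130-fold lower number from compound 2 to compound 4 (2.12 log units; beyond the scatter) and a 23-fold lower number from compound 1 to compound 4 (1.36 log units; beyond the scatter) for 4-(methoxycarbonyl)phenyl, so the aryl-over-alkyl step no longer rests on compound 3 alone. Methoxycarbonyl in place of trifluoromethyl on the aromatic carbon gives a 1.8-fold lower number from compound 3 to compound 4 (0.26 log units; within the scatter) and so separates the two aryl groups by no more than the scatter. Nothing measured here accounts for the difference between aryl and alkyl on this oxygen.

Open, on these data alone, is whether a carboxylic acid or an amine in place of methoxycarbonyl keeps these values, and whether unsubstituted phenyl on the oxygen does the same.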